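Replacing the 2,4,5-Trichlorophenyl Group of Compound 3

This account rests on a few compounds, and the source may have more. Where it says the series, first, only, none or still open, it means among the compounds named here.

In a functional assay on MCF7 cells (Homo sapiens) for antiproliferative activity, read by sulforhodamine B assay, with a stated time of 48 h (a higher number here means a weaker inhibitor, a lower number a stronger inhibitor), compound 1 `CCCN1CCN(c2ccc(S(=O)(=O)Oc3ccccc3CC)cc2)C1=O` gives 2300 nM and compound 2 `CCCN1CCN(c2ccc(S(=O)(=O)Oc3ccc(C)cc3C)cc2)C1=O` gives 1500 nM, which is a 1.5-fold lower number from compound 1 to compound 2 (0.19 log units; within the scatter). Compound 3 `CCCN1CCN(c2ccc(S(=O)(=O)Oc3cc(Cl)c(Cl)cc3Cl)cc2)C1=O` has the highest number of the three, at 13000 nM. Compound 4 `CCCN1CCN(c2ccc(S(=O)(=O)Oc3cccc(C)c3)cc2)C1=O` differs from it by 3-methylphenyl in place of 2,4,5-trichlorophenyl on an oxygen, with 3-methylphenyl in place of 2,4,5-trichlorophenyl on an oxygen. Two measured steps introduce the group that leaves here: a 5.7-fold higher number from compound 1 to compound 3 (0.75 log units; beyond the scatter) and an 8.7-fold higher number from compound 2 to compound 3 (0.94 log units; beyond the scatter). Neither step tests 3-methylphenyl itself, but removing that group is expected to reverse a change of similar size. The expected change is a 6.5-fold lower number from compound 3 to compound 4 (0.81 log units; beyond the scatter), towards a lower number and beyond the scatter. Compound 4 is estimated at 2000 nM, within a range of 600 nM to 6000 nM.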

Compound 4, half-maximal inhibitory concentration: 86000 nM
For compound 4 the middle estimate is 43-fold (1.63 log units) below the measured one; the measured number lies above the stated range.
By their numbers in this assay, from the lowest: compounds 2 and 1 (each within the scatter of the next); then compound 3; then compound 4.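

In this assay, 3-methylphenyl is the weakest of the four groups on this oxygen (a 6.6-fold higher number from compound 3 to compound 4 (0.82 log units; beyond the scatter)), so 2,4,5-trichlorophenyl does not mark the low end at this position. The loss is far larger against the other two methyl- or ethyl-bearing groups (a 57-fold higher number from compound 2 to compound 4 (1.76 log units; beyond the scatter); a 37-fold higher number from compound 1 to compound 4 (1.57 log units; beyond the scatter)), so carrying a small carbon substituent does not by itself keep the lower numbers. No measurement shown here accounts for these gaps.

Going by these compounds, it remains open whether 2-methylphenyl or 4-methylphenyl would restore the lower numbers. On these data alone, the effect of an amine or a carboxylic acid on this phenyl group also remains open.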